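Fluoro on the benzyl group in a thiopurine series

The source may report more compounds than this note shows. Statements on the series, on what has been measured and on what is new or still open speak of the compounds shown alone.

Measured so far in an assay on isolated protein for inhibition of RAC-alpha serine/threonine-protein kinase (Homo sapiens), tested at 30 uM; on this read-out lower numbers stand for less inhibition and higher numbers for more inhibition at the one concentration tested (going by the name of the read-out):
compound 1 `Cn1cnc2c(Sc3ccccc3)ncnc21` gives 0%
compound 2 `Nc1ncnc2c1ncn2Cc1ccc(F)cc1` gives 0%
compound 3 `c1ccc(Cn2cnc3c(Sc4ccccc4)ncnc32)cc1` gives 1%

All three numbers sit together within the scatter; compound 3 is the highest of the three only in a nominal sense, and no order can be read among them. For the measured compounds named here, the one step that can be followed, a number 1 percentage points higher from compound 1 to compound 3 (within the scatter), adds the whole phenyl to the chain carbon and still moves nothing beyond the scatter.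

Compound 4 `Fc1ccc(Cn2cnc3c(Sc4ccccc4)ncnc32)cc1` has not yet been measured in this assay. It differs from compound 3 in one place: fluoro in place of hydrogen on an aromatic carbon. Cut one bond further out this reads phenyl to 4-fluorophenyl, or benzyl to 4-fluorobenzyl. Going by the values given here, no measured step covers a fluoro; compound 2 carries the same 4-fluorobenzyl on another core and gives a value in the same flat range. Since the larger change from compound 1 to compound 3 stayed flat, a step of about no change at the digits printed from compound 3 to compound 4 (within the scatter) is expected, none beyond the scatter. Compound 4 is therefore estimated at 1%, in the range -8% to 10%.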

Compound 4, a percentage reported as inhibition, at one concentration (the size of the read-out at that concentration, not a potency): 13%
For compound 4 the middle estimate is 12 percentage points below the measured one, outside the stated range (above it).
By their numbers in this assay, from the lowest: compounds 1, 2 and 3 (each within the scatter of the next); then compound 4.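

In this assay, for the compounds shown here, the fluoro is the first single change to clear the scatter: the step is a number 12 percentage points higher from compound 3 to compound 4 (beyond the scatter) while adding the whole phenyl gave only a number 1 percentage points higher from compound 1 to compound 3 (within the scatter) in the same series. The 4-fluorobenzyl group does not give this reading on every core, since phenylsulfanyl in place of amino gives a number 13 percentage points higher from compound 2 to compound 4 (beyond the scatter) and the 4-fluorophenyl change on the saturated chain carbon gives a number 13 percentage points higher from compound 1 to compound 4 (beyond the scatter) as a modest step. No available evidence bears on why the fluoro has this effect.

Going by these compounds, it remains open whether chloro or methoxy in place of the fluoro on the same aromatic carbon would give a similar step. On these data alone, it also remains open whether an amine on the phenylsulfanyl ring would keep it, and a reading at one concentration gives no potency for compound 4.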